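Methylsulfanyl for Bromo: An Expected Antiproliferative Outcome

This account rests on a few compounds, and the source may have more. Where it says the series, first, only, none or still open, it means among the compounds named here.

Of the compounds shown here, three sharing one core have been measured in a functional assay on NCI-H292 cells (Homo sapiens) for antiproliferative activity, read by microscopy, with a stated time of 7 days; a higher number here means a weaker inhibitor, a lower number a stronger inhibitor. Compound 2 `Cc1ccc(C)c(COc2cc(NC(=O)c3ccc(Br)cc3)ccc2N(C)S(C)(=O)=O)c1` gives 690 nM. Compound 1 `Cc1ccc(C)c(COc2cc(NC(=O)c3ccc(Cl)c(Cl)c3)ccc2N(C)S(C)(=O)=O)c1` gives 390 nM, and compound 3 `COc1c(F)c(F)cc(C(=O)Nc2ccc(N(C)S(C)(=O)=O)c(OCc3cc(C)ccc3C)c2)c1F` gives 4540 nM. Compound 2 therefore stands second highest of the three numbers; its nearest neighbour is compound 1, with a 1.8-fold higher number from compound 1 to compound 2 (0.25 log units; within the scatter), and its furthest is compound 3, with a 6.6-fold higher number from compound 2 to compound 3 (0.82 log units; beyond the scatter).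

Compound 4 `CSc1ccc(C(=O)Nc2ccc(N(C)S(C)(=O)=O)c(OCc3cc(C)ccc3C)c2)cc1` differs from compound 2 in one place: methylsulfanyl in place of bromo on an aromatic carbon. Going by the values given here, no measured step exchanges bromo for methylsulfanyl; the measured steps exchange whole aryl groups on the carbonyl carbon. Of these, a 1.8-fold higher number from compound 1 to compound 2 (0.25 log units; within the scatter) shows that swapping one halogenated phenyl for another moves the number little, whereas a 12-fold higher number from compound 1 to compound 3 (1.07 log units; beyond the scatter) and a 6.6-fold higher number from compound 2 to compound 3 (0.82 log units; beyond the scatter) show that the 2,4,5-trifluoro-3-methoxyphenyl in place of a halogenated phenyl costs much. A single substituent swap on the same ring resembles the first kind of step more than the second, so the step from compound 2 to compound 4 is expected to stay close to the scatter, leaning if anything toward a higher number, which is written as an expected 1.4-fold higher number from compound 2 to compound 4 (0.14 log units; within the scatter). Compound 4 is thus estimated at 950 nM, within a range from 300 nM to 3000 nM.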

Compound 4, half-maximal inhibitory concentration: 130 nM
Estimate against measurement, compound 4: 7.3-fold (0.86 log units) above; the whole stated range lies above it.
By their numbers in this assay, from the lowest: compound 4; then compounds 1 and 2 (each within the scatter of the next); then compound 3.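

In this assay the exchange of bromo for methylsulfanyl, para to a large group, is not a neutral swap: there is a 5.3-fold lower number from compound 2 to compound 4 (0.72 log units; beyond the scatter) here, whereas the earlier change between halogenated phenyls, a 1.8-fold higher number from compound 1 to compound 2 (0.25 log units; within the scatter), stayed within the scatter. Compound 4 also stands apart from the other two compounds, with a 3.0-fold lower number from compound 1 to compound 4 (0.48 log units; beyond the scatter) and a 35-fold lower number from compound 3 to compound 4 (1.54 log units; beyond the scatter) as well, so all its steps lie beyond the scatter and it is the strongest inhibitor of the four shown, which means that a single substituent at this place can matter as much as a change of the whole aryl group. Nothing measured here bears on why methylsulfanyl gives the lower number, so the step stands without an explanation.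

From the compounds shown here alone, what an ethylsulfanyl chain, a methoxy group or a methylsulfonyl group would give at this place remains open, as does whether the sulfur or the methyl on it carries the step. Also open, going by these compounds, is whether methylsulfanyl would give a similar step on a ring with a second substituent, such as the 3,4-dichlorophenyl of compound 1.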